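Stability Tracked Across a Repeated Substitution

The source may hold more compounds than are shown below. What is called first, only, known or untested is meant among the compounds shown, and "the series" means these compounds.

Compound 1 `CO[C@H]1C(=O)N2C(C(=O)c3ccccc3)=C(C)CS(=O)(=O)C12` gives 26 h in a physicochemical assay, at pH 7.4; a higher number here means that the compound lasts longer, a lower number that the compound disappears faster. Compound 2 `CO[C@H]1C(=O)N2C(C(=O)c3ccccc3)=C(CSc3nnnn3C)CS(=O)(=O)C12` carries the change (1-methyl-1H-tetrazol-5-yl)sulfanyl in place of hydrogen on a saturated chain carbon bound to a double-bonded ring carbon and in this assay compound 2 gives 17 h; the step is a 1.5-fold lower number from compound 1 to compound 2 (0.18 log units; within the scatter). Compound 3 `CO[C@H]1C(=O)N2C(C(=O)C(C)(C)C)=C(C)[C@@H](Sc3nnnn3C)S(=O)(=O)C12` stands on a different core, and the difference between the core of compound 3 and the core of compound 1 is not broken down here. In this assay compound 3 gives 18 h. Compound 4 `CO[C@H]1C(=O)N2C(C(=O)C(C)(C)C)=C(CSc3nnnn3C)[C@@H](Sc3nnnn3C)S(=O)(=O)C12` has not yet been measured; it differs from compound 3 by (1-methyl-1H-tetrazol-5-yl)sulfanyl in place of hydrogen on a saturated chain carbon bound to a double-bonded ring carbon, the same change that separates compound 1 from compound 2, at a place described in the same words. Because the earlier step of a 1.5-fold lower number from compound 1 to compound 2 (0.18 log units; within the scatter) stayed within the scatter, a step of similar size, a 1.5-fold lower number from compound 3 to compound 4 (0.18 log units; within the scatter), is expected here. Compound 4 is estimated at 12 h, between 7 h and 24 h.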

Compound 4, half-life: 31 h
Beside the measured number, compound 4's estimate is 2.6-fold (0.41 log units) below it; measured number outside the range, above it.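

In this assay the change gives a 1.7-fold higher number from compound 3 to compound 4 (0.24 log units; within the scatter), and on the core of compound 1 it gave a 1.5-fold lower number from compound 1 to compound 2 (0.18 log units; within the scatter). Neither step on its own shows an effect of the change on either core, and the two opposite directions do not establish that the core decides how the change acts, nor that the change carries over unaltered. Nothing shown bears on why these numbers fall as they do.

From the compounds shown here alone, whether an amine or a carboxylic acid in place of the (1-methyl-1H-tetrazol-5-yl)sulfanyl would move the half-life beyond the scatter remains open. So does the outcome for a longer chain at this place.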